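A dichlorobenzyl sulfide weighed against two inactive analogues

The compounds below may be only part of what the source reports. "The series", "measured", "known", "first", "only" and "open" are said of these compounds alone.

Of the compounds shown here, two of a shared core have been tested in an ADME assay on A-431 cells (Homo sapiens) for cytotoxicity, with a stated time of 48 h; a lower number here means a stronger inhibitor, a higher number a weaker inhibitor. Compound 1 `O=[N+]([O-])c1cc(CSc2nnc(-c3ccccc3)n2C2CCCCC2)cc([N+](=O)[O-])c1` reaches only the limit of the assay, > 30000 nM. Compound 2 `CSc1nnc(-c2cc([N+](=O)[O-])cc([N+](=O)[O-])c2)n1Cc1ccccc1` likewise gives only a limit, > 30000 nM. Compound 2 thus stands at the limit of > 30000 nM in this assay, at which 2 of the 2 values shown sit, alongside compound 1, and neither result is a number. No measured step joins any pair of these compounds, so no direction has been established for any change in this series. Compound 3 `O=[N+]([O-])c1cc(-c2nnc(SCc3ccc(Cl)c(Cl)c3)n2Cc2ccccc2)cc([N+](=O)[O-])c1` differs from compound 2 by 3,4-dichlorophenyl in place of hydrogen on a saturated chain carbon bound to a sulfur. Among the compounds with values here, with no measured step to draw on, the expected step from compound 2 to compound 3 is a step that the limit leaves unreadable from compound 2 to compound 3 in this assay, not clearly beyond the scatter. Because compound 2 sits at the limit of > 30000 nM in this assay, at which 2 of the 2 values shown sit, compound 3 is expected most often to return only a limit as well. Compound 3 is estimated at 40000 nM, within a range from 8000 nM to 200000 nM.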

Compound 3, half-maximal inhibitory concentration: > 30000 nM
Compound 3: only a limit was reported; the forecaster's own chance of this, stated with the estimate: 75%; the middle value lies beyond the limit too.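

Compound 3 returns only a limit, > 30000 nM, and compound 2 is also a limit, so no step can be read from compound 2 to compound 3. The compounds shown leave open whether any change to the shared core gives a measurable value in this assay.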